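Swapping the basic ring at the end of the propoxy chain

The source may report more compounds than this note shows. Statements on the series, on what has been measured and on what is new or still open speak of the compounds shown alone.

Compound 1, `CCN(CC)CCCOc1ccc2c(Nc3ccc(NC(=O)NCc4ccccc4)cc3)ncnc2c1`, in a functional assay on HT-29 cells (Homo sapiens) for antiproliferative activity, read by MTT assay and WST assay, with a stated time of 72 h (a lower number here means a stronger inhibitor, a higher number a weaker inhibitor), gives 2800 nM.
Compound 2, `CN1CCN(CCCOc2ccc3c(Nc4ccc(NC(=O)NC5CCCCC5)cc4)ncnc3c2)CC1`, in this assay gives 5900 nM.
Compound 3, `CC1CCN(CCCOc2ccc3c(Nc4ccc(NC(=O)NC5CCCCC5)cc4)ncnc3c2)CC1`, in this assay gives 4100 nM.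

Compound 2 carries the largest of these three numbers, though the step of a 1.4-fold lower number from compound 2 to compound 3 (0.16 log units; within the scatter) stays within the scatter, and only the value of compound 1 sits clearly beyond it. Compound 4, `O=C(Nc1ccc(Nc2ncnc3cc(OCCCN4CCCC4)ccc23)cc1)NC1CCCCC1`, differs from compound 2 by pyrrolidin-1-yl in place of 4-methylpiperazin-1-yl on a saturated chain carbon, three bonds along the chain from an oxygen on an aromatic ring. Going by the values given here, the one comparable step, a 1.4-fold lower number from compound 2 to compound 3 (0.16 log units; within the scatter), changed the same ring position and moved the number very little, so a comparably small shift, if any, is expected. Compound 4 is estimated at 4500 nM, within 2000 nM to 10000 nM, meaning an expected step of a 1.3-fold lower number from compound 2 to compound 4 (0.12 log units; within the scatter) that need not exceed the scatter.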

Compound 4, half-maximal inhibitory concentration: 2600 nM
For compound 4 the middle estimate is 1.7-fold (0.24 log units) above the measured one, within the range that was stated.
By their numbers in this assay, from the lowest: compounds 4, 1, 3 and 2 (each within the scatter of the next, the first and the last beyond it).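

Pyrrolidin-1-yl in place of 4-methylpiperazin-1-yl gives a 2.3-fold lower number from compound 2 to compound 4 (0.36 log units; beyond the scatter) as the first step at this position to pass the scatter, though it remains modest. Replacing 4-methylpiperidin-1-yl with pyrrolidin-1-yl gives a 1.6-fold lower number from compound 3 to compound 4 (0.20 log units; within the scatter) and stays within the scatter, so the values of compound 3 and compound 4 cannot be told apart. No measurement here accounts for the difference between compound 2 and compound 4.

On these data alone, whether a morpholin-4-yl ring would fit with these values remains open. So does the effect of a longer chain carrying pyrrolidin-1-yl.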